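A few compounds are considered here, and "the series" means these few. Any claim that something is new, unique, unknown or untested is made for them only; others in the source may bear on it.

Notes on the tert-butyl ester side chains. In a functional assay (strain AB) with Danio rerio as the target, read by microscopy, with a stated time of 1 h (a higher number here means that more compound is needed for the effect, a lower number that less compound is needed), compound 1 `CC(C)(C)OC(=O)CCN1CCc2c(sc(NC(=O)Nc3ccc(Cl)cc3)c2C(N)=O)C1` gives 1100 nM and compound 2 `NC(=O)c1c(NC(=O)Nc2ccc(Cl)cc2)sc2c1CCN(CC1CCCC1)C2` gives 1830 nM. These two values lie within the scatter of each other: a 1.7-fold higher number from compound 1 to compound 2 (0.22 log units; within the scatter).

Compound 3 `CC(C)(C)OC(=O)CN1CCc2c(sc(NC(=O)Nc3ccc(Cl)cc3)c2C(N)=O)C1` is known only as a limit, > 25000 nM. Its two measured steps are both large and beyond the scatter: an at least 22-fold higher number from compound 1 to compound 3 (1.35 log units; beyond the scatter) and an at least 13-fold higher number from compound 2 to compound 3 (1.13 log units; beyond the scatter). It therefore stands as the least active of the three.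

Compound 4 `CC(C)(C)OC(=O)CCCCCN1CCc2c(sc(NC(=O)Nc3ccc(Cl)cc3)c2C(N)=O)C1` differs from compound 3 in one place: 4-(tert-butoxycarbonyl)butyl in place of tert-butoxycarbonyl on a saturated chain carbon bound to an amine nitrogen in a ring. The group that enters is 4-(tert-butoxycarbonyl)butyl, and the tert-butoxycarbonyl it replaces sits on a saturated chain carbon bound to an amine nitrogen in a ring.

Within the data shown here, the closest precedent is an at least 22-fold higher number from compound 1 to compound 3 (1.35 log units; beyond the scatter), which concerns the same place and also the ester with and without an added chain; read in reverse, it points to a lower number for the longer group. The result for compound 2, 1830 nM, adds that a quite different group at this place also gives a measurable value. No chain longer than that of compound 1 has been measured, so the extrapolation is loose.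

A large step toward a lower number is expected, estimated as an at least 12-fold lower number from compound 3 to compound 4 (1.09 log units; beyond the scatter). For compound 4 the expected value is 2000 nM, with an estimated range of 400 nM to 12000 nM.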

Compound 4, half-maximal effective concentration: 620 nM
Beside the measured number, compound 4's estimate is 3.2-fold (0.51 log units) above it; measured number inside the range.
By their numbers in this assay, from the lowest: compounds 4, 1 and 2 (each within the scatter of the next, the first and the last beyond it). At a limit, above all of these: compound 3.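

In this assay the tert-butyl ester keeps a measurable value on a chain much longer than that of compound 1, and the result at the shortest chain is reversed: an at least 40-fold lower number from compound 3 to compound 4 (1.60 log units; beyond the scatter). Compound 3 counts here only as a limit, so that step gives a bound and not a size: the limit of > 25000 nM in this assay, at which 1 of the 4 values shown sits. Going past the chain of compound 1 gives no readable difference, a 1.8-fold lower number from compound 1 to compound 4 (0.25 log units; within the scatter), so among the ester chains shown a clear dependence on length appears only at the short end, while 4-(tert-butoxycarbonyl)butyl does separate from the cyclopentyl group of compound 2, a 3.0-fold lower number from compound 2 to compound 4 (0.47 log units; beyond the scatter), a separation that compound 1 does not show.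

As far as these compounds go, it remains open whether a still longer chain holds this level or loses it, and where between the shortest chain and that of compound 1 the sharp change lies. The compounds shown also leave open whether the tert-butyl ester itself matters, which a carboxylic acid or an amine at the chain end would test.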